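Swapping Methyl for Fluoro on the Pendant Phenyl Ring

The source may report more compounds than this note shows. Statements on the series, on what has been measured and on what is new or still open speak of the compounds shown alone.

Measured compounds:
- compound 1, `Nc1cccc(-c2cn3nc(Cc4ccccc4)sc3n2)c1`: 24000 nM
- compound 2, `Cc1ccc(-c2nn3cc(-c4cccc(N)c4)nc3s2)cc1`: 8900 nM

In a functional assay on HeLa cells (Homo sapiens) for inhibition, read by cell counting, with a stated time of 4 days (a higher number here means a weaker inhibitor, a lower number a stronger inhibitor), compound 1 gives 24000 nM and compound 2 gives 8900 nM. Among the compounds with values here, compound 2 therefore holds the lower of the two numbers, and its only neighbour is compound 1, from which it differs by one change: a 2.7-fold lower number from compound 1 to compound 2 (0.43 log units; beyond the scatter). That step replaced a benzyl group with a 4-methylphenyl group on the shared core, so it changed how the pendant ring is attached rather than what sits on it.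

Compound 3, `Nc1cccc(-c2cn3nc(-c4ccc(F)cc4)sc3n2)c1`, keeps the 4-methylphenyl attachment of compound 2 and alters only the group on that ring: fluoro in place of methyl on an aromatic carbon. Within the data shown here, no measured pair shows the effect of exchanging one small group on this ring for another, so the single known step offers little guidance here. With the attachment unchanged, a step within the usual scatter is expected, in either direction. Compound 3 is therefore estimated at 10000 nM, with a range from 4000 nM to 25000 nM, which is expected to mean a 1.1-fold higher number from compound 2 to compound 3 (0.05 log units; within the scatter).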

Compound 3, half-maximal inhibitory concentration: >= 250000 nM
Compound 3: only a limit was reported (the forecaster's own chance of this, stated with the estimate: 10%); middle value at least 25-fold (1.39 log units) from the limit.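

The value of compound 3 in this assay is a limit of the assay and not a number: the limit of >= 250000 nM in this assay, at which 1 of the 3 values shown sits. Even so, it shows that this place on the ring, para to a large group, is far from indifferent to what sits there: exchanging methyl for fluoro, one heavy atom for one heavy atom, gives an at least 28-fold higher number from compound 2 to compound 3 (1.44 log units; beyond the scatter), a large step where the only earlier one was modest. The 4-fluorophenyl group also compares poorly with the benzyl group, with an at least 10-fold higher number from compound 1 to compound 3 (1.01 log units; beyond the scatter), so losing the benzyl group does not by itself lower the number, and among the compounds shown only the 4-methylphenyl group does so, with a 2.7-fold lower number from compound 1 to compound 2 (0.43 log units; beyond the scatter).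

Going by these compounds, how far compound 3 lies past its limit stays open, and two groups at this place cannot show what the ring requires there. On these data alone, whether a chloro, a methoxy or an amine at the same place would keep the number near that of compound 2 or lose it as compound 3 does is also open.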